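A few compounds are considered here, and "the series" means these few. Any claim that something is new, unique, unknown or untested is made for them only; others in the source may bear on it.

Measured so far in a functional assay (plasma) with Oryctolagus cuniculus as the target; a lower number here means a stronger inhibitor, a higher number a weaker inhibitor
- compound 1 `Cc1nc2cnccc2n1CC1CCN(C(=O)N[C@@H](C)c2ccccc2)CC1` gives 41 nM
- compound 2 `CCOC(=O)[C@@H](NC(=O)N1CCC(Cn2c(C)nc3cnccc32)CC1)c1ccccc1` gives 16 nM

Compound 2 holds the lower number of the two, and its gap to compound 1 lies beyond the scatter. Compound 3 `CCOC(=O)[C@H](NC(=O)N1CCC(Cn2c(C)nc3cnccc32)CC1)c1ccccc1` has the same atoms and bonds as compound 2 and differs only in configuration as drawn (the two compounds have the same atoms and bonds and differ only in configuration as drawn: 1 of 1 stereo elements differ; a stereocentre at a saturated chain carbon is drawn S in compound 2 and R in compound 3): a stereocentre at a saturated chain carbon is drawn S in compound 2 and R in compound 3. Among the compounds with values here, no measured pair shows what such a change does, so the estimate is uncertain. In this assay a weaker inhibitor is expected, with an estimated change of a 6.9-fold higher number from compound 2 to compound 3 (0.84 log units; beyond the scatter) (beyond the scatter). Compound 3 is expected near 110 nM (range 22 nM to 550 nM).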

Compound 3, half-maximal inhibitory concentration: 150 nM
Beside the measured number, compound 3's estimate is 1.4-fold (0.13 log units) below it; measured number inside the range.
By their numbers in this assay, from the lowest: compound 2; then compound 1; then compound 3.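

In this assay, the drawn configuration at this saturated chain carbon clearly matters, with the change from S to R giving a 9.4-fold higher number from compound 2 to compound 3 (0.97 log units; beyond the scatter). This step can be assigned to the stereocentre alone, because nothing else separates the two compounds: the fact that compounds 2 and 3 differ only in the configuration as drawn. Ethoxycarbonyl therefore does not bring a lower number by itself, since ethoxycarbonyl in place of methyl gives a 3.7-fold higher number from compound 1 to compound 3 (0.56 log units; beyond the scatter). On these data alone, whether a carboxylic acid or a longer ester chain at this carbon would show the same gap between S and R remains open.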